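The source may report more compounds than this note shows. Statements on the series, on what has been measured and on what is new or still open speak of the compounds shown alone.

Measured so far:
- compound 1, `CS(=O)(=O)/C(C#N)=C/c1c[nH]c2ccccc12`: > 100000 nM
- compound 2, `N#C/C(=C\c1c(-c2ccccc2)[nH]c2ccccc12)C(N)=O`: 6000 nM

Both compounds were tested in a functional assay on MT4 cells (Homo sapiens) for antiproliferative activity, read by MTT assay, with a stated time of 96 h; a lower number here means that less compound is needed, a higher number that more compound is needed for the effect. For compound 1 the result of > 100000 nM is a limit of the assay rather than a number, as set out in the limit of > 100000 nM in this assay, at which 1 of the 2 values shown sits. Among the compounds with values here, compound 2 is therefore the only compound with an actual number in this assay, giving 6000 nM, and it stands alone.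

Compound 3, `N#C/C(=C\c1c(-c2ccccc2)[nH]c2ccccc12)C(=O)Nc1ccc(Cl)cc1`, has not yet been measured. It differs from compound 2 in one place: 4-chlorophenyl in place of hydrogen on an amide-type nitrogen. Cut one bond further out, the same change reads as amino to (4-chlorophenyl)amino.

Within the data shown here, no step between two measured compounds is available to guide the size of this change. The expectation for the step from compound 2 to compound 3 in this assay is a 2.0-fold lower number from compound 2 to compound 3 (0.30 log units; within the scatter), a modest gain that may not exceed the usual scatter. Compound 3 is thus estimated at 3000 nM, within a range from 600 nM to 15000 nM.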

Compound 3, half-maximal effective concentration: 1700 nM
Compound 3: middle estimate off by 1.8-fold (0.25 log units), on the high side, and the stated range covers the measured number.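

Placing 4-chlorophenyl on the amide-type nitrogen gives, in this assay, a 3.5-fold lower number from compound 2 to compound 3 (0.55 log units; beyond the scatter) and this is the first change in the series whose size can be read as a number. It shows that this nitrogen, which carries only hydrogen in compound 2, can take an aromatic ring without the effect being lost, and that the number in fact moves modestly in the favourable direction, by more than the usual scatter of repeated measurements. No measurement shown gives a reason for this step.

The compounds shown leave open whether the step comes from the ring itself or from its chlorine, since a plain phenyl, a 4-methoxyphenyl or a 4-fluorophenyl on the same nitrogen would be needed to separate the two. They also leave open whether a ring is needed at all, or whether a small methyl group, a longer alkyl chain or a benzyl group with a carbon spacer on this nitrogen would move the number in the same way.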